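A few compounds are considered here, and "the series" means these few. Any claim that something is new, unique, unknown or untested is made for them only; others in the source may bear on it.

In a functional assay on SGC-7901 cells (Homo sapiens) for inhibition, read by MTT assay, with a stated time of 48 h (a higher number here means a weaker inhibitor, a lower number a stronger inhibitor), compound 1 `Cc1nnsc1CO/N=C/c1c(C)nn(C)c1Oc1ccc(F)cc1` reads > 50000 nM, which is a limit of the assay and not a number. For the measured compounds named here, compound 2 `Cc1nnsc1CO/N=C/c1c(C)nn(C)c1Oc1ccc(Br)cc1` gives 15200 nM, the only true number available so far. Putting bromo in place of fluoro on an aromatic carbon produced an at least 3.2-fold lower number from compound 1 to compound 2 (0.51 log units; beyond the scatter), a step beyond the scatter and the only measured one here. From the compounds shown here alone, its full size stays open because it rests on (the limit of > 50000 nM in this assay, at which 1 of the 2 values shown sits).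

Compound 3 `Cc1cccc(Oc2c(/C=N/OCc3snnc3C)c(C)nn2C)c1` is still unmeasured. It differs from compound 2 by 3-methylphenyl in place of 4-bromophenyl on an oxygen on an aromatic ring, so the bromo goes and a methyl arrives in a different place. The measured step bears on this only loosely, but it links bromo to the lower number. A modest move towards a weaker inhibitor is therefore expected, an estimated 1.8-fold higher number from compound 2 to compound 3 (0.27 log units; within the scatter). For compound 3, the expected value is 28000 nM, with an estimated range of 10000 nM to 60000 nM.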

Compound 3, half-maximal inhibitory concentration: 12800 nM
For compound 3 the middle estimate is 2.2-fold (0.34 log units) above the measured one; the range from low to high includes it.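

In this assay, the swap of 4-bromophenyl for 3-methylphenyl on the oxygen gives a 1.2-fold lower number from compound 2 to compound 3 (0.07 log units; within the scatter), so compound 2 and compound 3 read alike and bromo is not required for this level of inhibition. Moving away from 4-fluorophenyl also pays with this second group, as 3-methylphenyl in place of 4-fluorophenyl gives an at least 3.9-fold lower number from compound 1 to compound 3 (0.59 log units; beyond the scatter). The full size of that step stays open because compound 1 reads only as a limit of the assay: the limit of > 50000 nM in this assay, at which 1 of the 3 values shown sits.

Compound 3 changes both the group and its place on the ring, so the effect of each remains unseparated, and 4-methylphenyl would be the direct test. From the compounds shown here alone, how an amine or a carboxylic acid on the phenyl ring would read also stays open.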